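This account rests on a few compounds, and the source may have more. Where it says the series, first, only, none or still open, it means among the compounds named here.

Three compounds share one core and differ in the group carried on the amide-type nitrogen. Compound 1 `CC(C)CNC(=O)n1c(=O)oc2cc(C3CCN(C)CC3)ccc21` gives 166 nM in an assay on HEK293 cells for inhibition of acid ceramidase (Homo sapiens), read by fluorescence, with stated times of 10 min and 3 h; a lower number here means a stronger inhibitor, a higher number a weaker inhibitor. Compound 2 `CC(C)CNC(=O)n1c(=O)oc2c(C3CCN(C)CC3)cccc21`, which carries the same side group but places the ring substituent elsewhere on the core, gives 535 nM. Compound 3 `CN1CCC(c2ccc3c(c2)oc(=O)n3C(=O)NCCOCc2ccccc2)CC1` gives 215 nM. Among these three numbers compound 3 holds the second highest place: its value and that of compound 1 lie within the scatter of each other, so no order between them can be claimed, while compound 2 shows a clearly higher number than compound 3.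

Compound 4 `CCC(C)NC(=O)n1c(=O)oc2cc(C3CCN(C)CC3)ccc21` has not yet been measured. Compared with compound 3 the change is sec-butyl in place of 2-(benzyloxy)ethyl on an amide-type nitrogen. Within the data shown here, the one measured step that bears on this exchange is the move from compound 1 to compound 3, which gave a 1.3-fold higher number from compound 1 to compound 3 (0.11 log units; within the scatter). Swapping a small branched chain for the larger benzyl-bearing chain changed nothing beyond the scatter, so the reverse direction, returning to a small branched chain, is expected to change little as well. Compound 4 is therefore expected to give about 200 nM, with a plausible range from 90 nM to 450 nM, meaning an expected step of a 1.1-fold lower number from compound 3 to compound 4 (0.03 log units; within the scatter).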

Compound 4, half-maximal inhibitory concentration: 2100 nM
The estimate for compound 4 lay 11-fold (1.02 log units) below the measured number, outside the stated range (above it).
By their numbers in this assay, from the lowest: compounds 1 and 3 (each within the scatter of the next); then compound 2; then compound 4.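

In this assay, among these compounds, the chain on the amide-type nitrogen proves far less forgiving than the earlier compounds suggested: sec-butyl in place of isobutyl, a swap between two small branched chains, gives a 13-fold higher number from compound 1 to compound 4 (1.10 log units; beyond the scatter). Sec-butyl in place of 2-(benzyloxy)ethyl gives a 9.8-fold higher number from compound 3 to compound 4 (0.99 log units; beyond the scatter), so a small chain at this position does not by itself give a number like that of compound 1, and the number does not simply follow the size of the chain, since the far larger chain of compound 3 sits within the scatter of compound 1. Nothing shown here gives a measured reason for the sharp sensitivity to how the chain is branched.

As far as these compounds go, it remains open how a straight butyl chain, a tert-butyl group or a cyclohexyl ring would behave at this position, and whether the two mirror-image forms of sec-butyl would give the same number. From the compounds shown here alone, it is also open whether sec-butyl would have a similar effect on the core of compound 2, where the ring substituent sits elsewhere.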